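A few compounds are considered here, and "the series" means these few. Any claim that something is new, unique, unknown or untested is made for them only; others in the source may bear on it.

Compound 1 `Cc1cc(-c2nc3cc(Cl)ccc3o2)ccc1NC(=O)CCl` is one of three compounds tested in a functional assay on HepG2 cells (Homo sapiens) for cytotoxicity, read by MTT assay, with a stated time of 24 h (a lower number here means a stronger inhibitor, a higher number a weaker inhibitor), where compound 1 gives 35000 nM, the highest number of the three. Compound 3 `O=C(CCl)Nc1ccc(-c2nc3cc(F)ccc3o2)cc1` gives 8120 nM, and compound 2 `Cc1cc(-c2nc3ccccc3o2)ccc1NC(=O)CN1CCN(CCCN(C)C)CC1` gives 2160 nM; both gaps to compound 1 lie beyond the scatter, so compound 1 is the weakest inhibitor among those measured. Compound 4 `Cc1ccc2oc(-c3ccc(NC(=O)CCl)c(C)c3)nc2c1` has not yet been measured. It differs from compound 1 in one place: methyl in place of chloro on an aromatic carbon. Among the measured compounds shown here, no pair of measured compounds that differ in a single place is available, so there is no measured step to lean on. Exchanging the chloro for a methyl is expected to move the number little, with a step of a 1.2-fold lower number from compound 1 to compound 4 (0.07 log units; within the scatter) that stays within the usual scatter. Compound 4 is therefore estimated at 30000 nM, within a range from 12000 nM to 80000 nM.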

Compound 4, half-maximal inhibitory concentration: 54800 nM
Compound 4: the middle estimate sits 1.8-fold (0.26 log units) below what was measured; low and high end bracket the measured number.
By their numbers in this assay, from the lowest: compound 2; then compound 3; then compounds 1 and 4 (each within the scatter of the next).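

Among the compounds shown here, this is the first measured step between compounds that differ in one place: in this assay, methyl in place of chloro on this aromatic carbon gives a 1.6-fold higher number from compound 1 to compound 4 (0.19 log units; within the scatter). At this position on the core of compound 1, the two groups therefore cannot be told apart by this read-out. No measurement available here accounts for that result. One exchange between two single-atom groups says little about the position as a whole. As far as these compounds go, whether an amine, a carboxylic acid or a longer chain on this carbon would give a different number remains open.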